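Replacing the 1,3-benzoxazol-2-yl group of compound 3

A few compounds are considered here, and "the series" means these few. Any claim that something is new, unique, unknown or untested is made for them only; others in the source may bear on it.

Compound 1 `CC(C)(C)Sc1c(CC(C)(C)C(=O)O)n(Cc2ccc(Cl)cc2)c2ccc(OCc3ccc4cc(F)c(F)cc4n3)cc12`: > 3000 nM (a limit of the assay, not a number)
Compound 2 `CC(C)(C)Sc1c(CC(C)(C)C(=O)O)n(Cc2ccc(Cl)cc2)c2ccc(OCc3nc4ccccc4s3)cc12`: 260 nM
Compound 3 `CC(C)(C)Sc1c(CC(C)(C)C(=O)O)n(Cc2ccc(Cl)cc2)c2ccc(OCc3nc4ccccc4o3)cc12`: 2500 nM

All three compounds were tested in a functional assay (blood) for inhibition, with Homo sapiens as the target; on this read-out lower numbers stand for stronger inhibition and higher numbers for weaker inhibition. Of the two true numbers, compound 3 has the higher one, at 2500 nM, which makes it clearly weaker than compound 2. For compound 1, the reading of > 3000 nM is a limit. The step of an at least 1.2-fold lower number from compound 1 to compound 3 (0.07 log units; that floor lies within the scatter) does not separate the two compounds beyond the scatter.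

Compound 4 `C[C@H](COc1ccc2c(c1)c(SC(C)(C)C)c(CC(C)(C)C(=O)O)n2Cc1ccc(Cl)cc1)c1ccccn1` differs from compound 3 by one change (1-(pyridin-2-yl)ethyl in place of 1,3-benzoxazol-2-yl on a saturated chain carbon bound to an oxygen on an aromatic ring). It carries 1-(pyridin-2-yl)ethyl in place of 1,3-benzoxazol-2-yl on a saturated chain carbon bound to an oxygen on an aromatic ring.

Two measured steps at this same place bear on the change. The step of an at least 11-fold lower number from compound 1 to compound 2 (1.06 log units; beyond the scatter) is large, and the step of a 9.6-fold higher number from compound 2 to compound 3 (0.98 log units; beyond the scatter) is modest, so this place clearly matters in this assay. Among the compounds with values here, no measured compound carries a group like the new one, so these steps suggest how far the value could move but not in which direction. Compound 3 already lies toward the weak end at 2500 nM, so only a small drop is expected. The expected step is a 1.7-fold lower number from compound 3 to compound 4 (0.22 log units; within the scatter), which is an estimate within the scatter. Compound 4 is estimated at 1500 nM. The expected range for compound 4 runs from 300 nM to 6000 nM.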

Compound 4, half-maximal inhibitory concentration: 470 nM
Estimate against measurement, compound 4: 3.2-fold (0.50 log units) above; low and high end bracket the measured number.
By their numbers in this assay, from the lowest: compounds 2 and 4 (each within the scatter of the next); then compound 3. At a limit, above all of these: compound 1.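

In this assay, this place does not depend on a group with two aromatic rings: 1-(pyridin-2-yl)ethyl, with a single six-membered aromatic ring, gives a 5.3-fold lower number from compound 3 to compound 4 (0.73 log units; beyond the scatter). Set against the 1,3-benzothiazol-2-yl group, the step is a 1.8-fold higher number from compound 2 to compound 4 (0.26 log units; within the scatter), so the two groups cannot be told apart in this assay, and a good value here is not tied to the two-ring benzothiazole. Compound 1 remains a limit of the assay, so the remaining step sets only a floor, an at least 6.3-fold lower number from compound 1 to compound 4 (0.80 log units; beyond the scatter), and gives no exact size: the limit of > 3000 nM in this assay, at which 1 of the 4 values shown sits.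

The compounds shown do not separate the contributions of the parts of the new group, so a plain pyridin-2-ylmethyl group would show what the extra methyl on the chain adds, and a phenyl ring in place of the pyridine would show what the ring nitrogen adds. The new group also carries a defined stereocentre, and its mirror-image form would show whether that arrangement matters at this place.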